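Changing the nitrophenyl group of a dichlorophenyl compound

The source may hold more compounds than are shown below. What is called first, only, known or untested is meant among the compounds shown, and "the series" means these compounds.

In a functional assay on K562 cells (Homo sapiens) for cytotoxicity, read by MTT assay, with a stated time of 24 h (on this read-out lower numbers stand for stronger inhibition and higher numbers for weaker inhibition), compound 1 `CN1C/C(=C\c2ccc(Br)cc2)C(=O)/C(=C/c2cccc([N+](=O)[O-])c2)C1` gives > 20000 nM as a limit of the assay and not a number. Among the measured compounds shown here, compound 2 `CN1C/C(=C\c2cccc([N+](=O)[O-])c2)C(=O)/C(=C/c2ccc(Cl)cc2Cl)C1` gives 12400 nM and compound 3 `CN1C/C(=C\c2cccc([N+](=O)[O-])c2)C(=O)/C(=C/c2ccc(Cl)c(Cl)c2)C1` gives 15500 nM as the only two true numbers here. Between these two stands a 1.3-fold higher number from compound 2 to compound 3 (0.10 log units; within the scatter) and nothing more. For the measured compounds named here, compound 4 `CN1C/C(=C\c2ccc(C#N)cc2)C(=O)/C(=C/c2ccc(Cl)cc2Cl)C1` differs from compound 2 by 4-cyanophenyl in place of 3-nitrophenyl on a double-bonded chain carbon bound to a double-bonded ring carbon and no measured step touches that group. The measured steps change the other aromatic group, and an at least 1.6-fold lower number from compound 1 to compound 2 (0.20 log units; that floor lies within the scatter) and an at least 1.2-fold lower number from compound 1 to compound 3 (0.11 log units; that floor lies within the scatter) offer only floors. The expected step is therefore none beyond the scatter, namely a 1.0-fold lower number from compound 2 to compound 4 (0.01 log units; within the scatter) as an estimate. In this assay compound 4 is estimated at 12000 nM within an expected range of 5000 nM to 20000 nM for now.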

Compound 4, half-maximal inhibitory concentration: 11900 nM
Compound 4: the middle estimate sits 1.0-fold (0.00 log units) above what was measured; the range from low to high includes it.
By their numbers in this assay, from the lowest: compounds 4, 2 and 3 (each within the scatter of the next). At a limit, above all of these: compound 1.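

In this assay, among the compounds shown here, the first change at this place, 4-cyanophenyl in place of 3-nitrophenyl, gives a 1.0-fold lower number from compound 2 to compound 4 (0.02 log units; within the scatter). With 2,4-dichlorophenyl as the other aromatic group, the 3-nitrophenyl group is therefore not needed to keep the number at this level. Nothing given here accounts for this match between the two groups.

As far as these compounds go, it remains open whether an amine or a carboxylic acid on this phenyl ring would move the number beyond the scatter. Also open, from the compounds shown here alone, is whether the same swap would hold with the 3,4-dichlorophenyl group of compound 3.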